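The source may report more compounds than this note shows. Statements on the series, on what has been measured and on what is new or still open speak of the compounds shown alone.

Working notes on the series. The three measured compounds share one core; in an assay on isolated protein for inhibition of aldehyde dehydrogenase 1A1 (Homo sapiens), read by spectrophotometry, tested at 10 uM (on this read-out lower numbers stand for less inhibition and higher numbers for more inhibition at the one concentration tested (going by the name of the read-out)), compound 1 `CCn1c(CN2CCN(C(=O)C3CC3)CC2)nc2ccccc21` gives 20.8%, the lowest of the three numbers. Among the measured compounds shown here, compound 3 `Cc1cccc(Cn2c(CN3CCN(C(=O)C4CCCCC4)CC3)nc3ccccc32)c1` gives 31.9% in this assay, and compound 2 `Cc1cccc(Cn2c(OC3CCN(C(=O)c4ccco4)CC3)nc3ccccc32)c1` gives 68.3%; both of these sit beyond the scatter above compound 1, but each differs from compound 1 in more than one place, so no single step can be drawn from them. Compound 4 `CC(C)CCn1c(CN2CCN(C(=O)C3CC3)CC2)nc2ccccc21` is not yet measured. For the measured compounds named here, its only change from compound 1 is isopropyl in place of hydrogen on a saturated chain carbon, two bonds along the chain from an aromatic nitrogen. Both higher numbers in the set carry a larger group on the aromatic nitrogen, which is the only lead available. A moderate upward step is therefore expected, a number 11.2 percentage points higher from compound 1 to compound 4 (beyond the scatter), and compound 4 is estimated at 32% with a range from 12% to 55%.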

Compound 4, a percentage reported as inhibition, at one concentration (the size of the read-out at that concentration, not a potency): 70%
Compound 4: middle estimate off by 38 percentage points, on the low side; measured number outside the range, above it.
By their numbers in this assay, from the lowest: compound 1; then compound 3; then compounds 2 and 4 (each within the scatter of the next).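

Isopropyl in place of hydrogen on a saturated chain carbon, two bonds along the chain from an aromatic nitrogen, gives a number 49.2 percentage points higher from compound 1 to compound 4 (beyond the scatter) in this assay, the first step in the series that can be read at a single place. With the rest of compound 1 unchanged, this position alone can carry a large change in the read-out. Nothing measured here accounts for the size of the step.

As far as these compounds go, whether a straight butyl chain would give a similar step remains open, as does whether an amine or a carboxylic acid in place of isopropyl would keep it.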